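Fluoro for Methoxy on the Indole Ring of Compound 1

The compounds below may be only part of what the source reports. "The series", "measured", "known", "first", "only" and "open" are said of these compounds alone.

Compound 1, `COc1ccc2[nH]cc(-c3nc(C(=O)Nc4cc(OC)c(OC)c(OC)c4)cs3)c2c1`, was tested in a functional assay on LNCaP C4-2 cells (Homo sapiens) for cytotoxicity, read by MTT assay, with a stated time of 48 h, in the presence of a further agent that is not named here; a lower number here means a stronger inhibitor, a higher number a weaker inhibitor. In this assay compound 1 reaches only the assay limit, > 100000 nM, and no number is known for it. Compound 2, `O=C(Nc1ccccc1)c1csc(-c2c[nH]c3ccccc23)n1`, likewise shows only the limit of > 100000 nM in this assay. Compound 3, `COc1ccc(NC(=O)c2csc(-c3c[nH]c4ccc(F)cc34)n2)cc1`, also gives only the limit of > 100000 nM in this assay. All three values therefore stand at the same place, (the limit of > 100000 nM in this assay, at which 3 of the 3 values shown sit). Compound 4, `COc1cc(NC(=O)c2csc(-c3c[nH]c4ccc(F)cc34)n2)cc(OC)c1OC`, differs from compound 1 by fluoro in place of methoxy on an aromatic carbon. For the measured compounds named here, with no measured step to draw on, the step from compound 1 to compound 4 is expected to be a number no higher from compound 1 to compound 4 (the limit leaves the size open), none beyond the scatter. Compound 4 is thus estimated at 100000 nM, between 30000 nM and 300000 nM.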

Compound 4, half-maximal inhibitory concentration: > 100000 nM
Compound 4: a limit, no number; the forecaster's own chance of this, stated with the estimate: 85%; the middle value lies on the limit itself.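

For the compounds shown here, compound 1 and compound 4 both stand only at the limit of this assay, so no step between them can be read. The compounds shown leave open what change, if any, would give a readable number there.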